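The source may report more compounds than this note shows. Statements on the series, on what has been measured and on what is new or still open speak of the compounds shown alone.

Compound 3 `Nc1cc(N)c2nc(-c3ccccc3)c(NCc3ccc(F)cc3)nc2c1` in a functional assay on SW-620 cells (Homo sapiens) for inhibition, read by sulforhodamine B assay, with a stated time of 48 h (a lower number here means a stronger inhibitor of growth, a higher number a weaker inhibitor of growth), gives 2190 nM. Compound 1 `Nc1cc(N)c2nc(-c3ccccc3)c(NCc3ccc(Cl)c(Cl)c3)nc2c1` gives 3240 nM, and compound 2 `COc1ccc(CNc2nc3cc(N)cc(N)c3nc2-c2ccccc2)cc1OC` gives 5250 nM. The measured steps are a 1.5-fold lower number from compound 1 to compound 3 (0.17 log units; within the scatter), a 1.6-fold higher number from compound 1 to compound 2 (0.21 log units; within the scatter) and a 2.4-fold lower number from compound 2 to compound 3 (0.38 log units; beyond the scatter), so compound 3 sits within the scatter of compound 1 and is set apart from compound 2 only by a modest step. Compound 4 `Nc1cc(N)c2nc(-c3ccccc3)c(Sc3ccc(F)cc3)nc2c1` differs from compound 3 by (4-fluorophenyl)sulfanyl in place of (4-fluorobenzyl)amino on an aromatic carbon. Going by the values given here, each measured step changes only the substitution of the outer aromatic ring; none changes the link between that ring and the core, so no measured step bears on this change, and its direction cannot be read from the series. The expected step is a 1.4-fold higher number from compound 3 to compound 4 (0.14 log units; within the scatter), with wide uncertainty. Compound 4 is estimated at 3000 nM, between 800 nM and 12000 nM.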

Compound 4, concentration for 50% growth inhibition: 22900 nM
Estimate against measurement, compound 4: 7.6-fold (0.88 log units) below; measured number outside the range, above it.
By their numbers in this assay, from the lowest: compounds 3, 1 and 2 (each within the scatter of the next, the first and the last beyond it); then compound 4.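

In this assay, going by these compounds alone, the link joining the outer ring to the shared core matters more than anything the earlier compounds varied: a 10-fold higher number from compound 3 to compound 4 (1.02 log units; beyond the scatter), a larger step than any among compound 1, compound 2 and compound 3. The 4-fluorophenyl ring stays in both compounds, so the step belongs to the replaced link, where the sulfur stands for the amino nitrogen and the chain carbon is gone. No available evidence explains the step.

On these data alone, whether the sulfur or the missing chain carbon carries the step remains open. A (4-fluorobenzyl)sulfanyl or (4-fluorophenyl)amino group would separate the two.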